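Swapping a phenyl for a methyl on compound 3

The source may report more compounds than this note shows. Statements on the series, on what has been measured and on what is new or still open speak of the compounds shown alone.

Compound 1 `O=C1N=C(Nc2ccc(O)cc2)S/C1=C/c1ccc(N2CCNCC2)cc1`: 13.9 ug/mL
Compound 2 `CCN(CC)c1ccc(/C=C2/SC(N(c3ccccc3)c3ccccc3)=NC2=O)cc1`: 0.01 ug/mL
Compound 3 `O=C1N=C(N(c2ccccc2)c2ccccc2)S/C1=C/c1ccc(N2CCNCC2)cc1`: 0.15 ug/mL

All three values come from a physicochemical assay (Homo sapiens) for solubility, with a stated time of 18 h, at pH 7.4; on this read-out higher numbers stand for higher solubility and lower numbers for lower solubility. Compound 3 stands in the middle of the three, above compound 2 and below compound 1.

Compound 4 `CN(C1=NC(=O)/C(=C\c2ccc(N3CCNCC3)cc2)S1)c1ccccc1` keeps the shared core and the piperazin-1-yl group of compound 3 and changes one thing: methyl in place of phenyl on a nitrogen on an aromatic ring. In words, it carries methyl in place of phenyl on a nitrogen on an aromatic ring.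

For the measured compounds named here, no measured step covers this change directly. The only one, a 15-fold higher number from compound 2 to compound 3 (1.18 log units; beyond the scatter), is piperazin-1-yl in place of diethylamino on an aromatic carbon, which is a different place in the molecule. It shows that one swap here can move the number well beyond the scatter, but it cannot set the size of this one. Compound 1 differs from compound 3 on that same nitrogen, and the two values show how wide the range can be: compound 3 gives 0.15 ug/mL and compound 1 gives 13.9 ug/mL.

A large upward step in this assay is therefore expected, though one that stops short of that whole gap. The expected step is a 13-fold higher number from compound 3 to compound 4 (1.12 log units; beyond the scatter). For compound 4 the estimate is 2 ug/mL, with an expected range of 0.4 ug/mL to 12 ug/mL.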

Compound 4, solubility: 3.89 ug/mL
Compound 4: middle estimate off by 1.9-fold (0.29 log units), on the low side, within the range that was stated.
By their numbers in this assay, from the lowest: compound 2; then compound 3; then compound 4; then compound 1.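

In this assay, the step at this nitrogen now stands alone: methyl in place of phenyl gives a 26-fold higher number from compound 3 to compound 4 (1.41 log units; beyond the scatter) with the shared core and the piperazin-1-yl group unchanged, so a single swap at this position can produce a large change. By the counts for the two groups, the swap removes a six-membered aromatic ring and five heavy atoms' worth of carbon, while hydrogen-bond donors, hydrogen-bond acceptors and net charge stay the same on both sides. Compound 1 still stays ahead, with a 3.6-fold lower number from compound 1 to compound 4 (0.55 log units; beyond the scatter) when methyl(phenyl)amino takes the place of (4-hydroxyphenyl)amino on a carbon with a double bond to nitrogen, so the methyl swap closes much of the gap but not all of it, and nothing measured here explains either step.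

An ethyl group or a longer chain on this nitrogen would show whether the number keeps changing with the size of the group or whether methyl is a special case. The same methyl swap on compound 2, with its diethylamino group in place of piperazin-1-yl, would show whether the large step carries over to a different group elsewhere on the molecule.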